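The compounds below may be only part of what the source reports. "The series", "measured", "known", "first", "only" and "open" are said of these compounds alone.

Of the compounds shown here, three sharing one core have been measured in an ADME assay on the whole organism (plasma, Macaca fascicularis) for protein binding, read by LC-MS, using equilibrium dialysis and cassette dosing, with a stated time of 24 h, at a dose of 1 mg/kg by the oral route; a higher number here means a larger unbound share of the compound, a lower number a smaller unbound share. Compound 1 `CCCCN(c1nc2ccccc2o1)[C@H](C)c1ccc(-c2ccccc2-c2nnn[nH]2)cc1` gives 0.000713, which places it second highest of the three. Compound 2 `CCCCN(c1nc2c(C(=O)O)cccc2o1)[C@H](C)c1ccc(-c2ccccc2-c2nnn[nH]2)cc1` gives 0.000285, and compound 3 `CCCCN(c1nc2c(C(=O)NC)cccc2o1)[C@H](C)c1ccc(-c2ccccc2-c2nnn[nH]2)cc1` gives 0.000975. Replacing the aromatic hydrogen of compound 1 gave a 2.5-fold lower number from compound 1 to compound 2 (0.40 log units; beyond the scatter) when carboxy entered, but only a 1.4-fold higher number from compound 1 to compound 3 (0.14 log units; within the scatter) when methylcarbamoyl entered; between those two, a 3.4-fold higher number from compound 2 to compound 3 (0.53 log units; beyond the scatter).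

Compound 4 `CCCCN(c1nc2c(-c3ccccn3)cccc2o1)[C@H](C)c1ccc(-c2ccccc2-c2nnn[nH]2)cc1` alters the same position of compound 1 in a third way: pyridin-2-yl in place of hydrogen on an aromatic carbon. The two measured changes at this position moved the unbound fraction in different directions, one beyond and one within the scatter, so they point only loosely toward what a neutral, uncharged ring will do. The expected outcome for compound 4 is a 1.6-fold lower number from compound 1 to compound 4 (0.20 log units; within the scatter), a step that is estimated to stay inside the usual scatter. Compound 4 is therefore estimated at 0.00045 in this assay, with a range from 0.00015 to 0.0012.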

Compound 4, unbound fraction: 0.00129
Beside the measured number, compound 4's estimate is 2.9-fold (0.46 log units) below it; measured number above the stated range.
By their numbers in this assay, from the lowest: compound 2; then compounds 1, 3 and 4 (each within the scatter of the next).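

In this assay, a whole pyridin-2-yl ring on this aromatic carbon stays within the scatter of hydrogen, with a 1.8-fold higher number from compound 1 to compound 4 (0.26 log units; within the scatter), and of methylcarbamoyl, with a 1.3-fold higher number from compound 3 to compound 4 (0.12 log units; within the scatter). The new ring also widens the gap to carboxy, with a 4.5-fold higher number from compound 2 to compound 4 (0.66 log units; beyond the scatter), which leaves compound 2 as the only one of the four whose steps to all the others are beyond the scatter. Nothing measured here accounts for this difference.

A phenyl ring, which lacks the ring nitrogen of pyridin-2-yl, and an amine such as aminomethyl could each group with compounds 1, 3 and 4 or with compound 2, and the compounds shown do not settle which. On these data alone, every group shown sits on the same aromatic carbon, so the effect of these groups elsewhere on the shared core remains open.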